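A few compounds are considered here, and "the series" means these few. Any claim that something is new, unique, unknown or untested is made for them only; others in the source may bear on it.

Measured compounds:
compound 1, `CCN(C(=O)c1cc(C)ccc1-n1nccn1)[C@@H](C)Cn1ccc(-c2ccc(F)cn2)n1`: 1.61 nM
compound 2, `CCN(C(=O)c1cc(C)ccc1-n1nccn1)[C@H](C)Cn1ccc(-c2ccc(F)cn2)n1`: 250 nM

In a functional assay on cells for antagonist activity at Orexin receptor type 2 (Homo sapiens), read by fluorescence and calcium flux, with a stated time of 30 min (on this read-out higher numbers stand for weaker inhibition and lower numbers for stronger inhibition), compound 1 gives 1.61 nM, the lowest of the two numbers in hand; its nearest neighbour, compound 2, gives 250 nM. For the measured compounds named here, the only measured step is a 160-fold higher number from compound 1 to compound 2 (2.19 log units; beyond the scatter), and it arises from the fact that compounds 1 and 2 differ only in the configuration as drawn, the two compounds sharing every atom and bond.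

Compound 3, `Cc1ccc(-n2nccn2)c(C(=O)N(C)[C@@H](C)Cn2ccc(-c3ccc(F)cn3)n2)c1`, has not yet been measured. It differs from compound 1 by hydrogen in place of methyl on a saturated chain carbon bound to an amide-type nitrogen: seen one bond further out, an ethyl on the amide nitrogen becomes a methyl, with the stereocentre kept as in compound 1. Going by the values given here, no measured step addresses a change of this kind; the one step available concerns configuration only and says nothing about the length of the alkyl group on the amide nitrogen. Without a guide, the shortening of one chain carbon is expected to move the number little, if at all, in this assay. Compound 3 is therefore estimated to give 2.5 nM, within 0.8 nM to 8 nM, which means an expected step of a 1.6-fold higher number from compound 1 to compound 3 (0.19 log units; within the scatter).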

Compound 3, half-maximal inhibitory concentration: 5.68 nM
Beside the measured number, compound 3's estimate is 2.3-fold (0.36 log units) below it; the measured number falls inside the stated range.
By their numbers in this assay, from the lowest: compound 1; then compound 3; then compound 2.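

In this assay, the alkyl group on the amide nitrogen proves not to be a silent spot: going from ethyl to methyl gives a 3.5-fold higher number from compound 1 to compound 3 (0.55 log units; beyond the scatter), so removing this one carbon moves the number by more than the usual scatter, something the earlier pair, which differed only in configuration, could not show. The change is still much smaller than a 160-fold higher number from compound 1 to compound 2 (2.19 log units; beyond the scatter), and with methyl on the amide nitrogen compound 3 keeps a low number of 5.68 nM with the stereocentre drawn as in compound 1. Nothing in hand accounts for the step from ethyl to methyl.

The compounds shown leave open whether a propyl group, a longer chain or a cyclopropyl group on the amide nitrogen would lower the number further, raise it or leave it in place, and what the amide nitrogen would do with a hydrogen in place of the alkyl group. Also open is whether the large gap between the two configurations holds with methyl on the amide nitrogen, as among the compounds shown the stereocentre varies only with ethyl there.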